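Oxane for Cyclopentyl on an Amide Already at the Limit

The compounds below may be only part of what the source reports. "The series", "measured", "known", "first", "only" and "open" are said of these compounds alone.

In an assay on HEK293 cells for negative allosteric modulation of metabotropic glutamate receptor 5 (Homo sapiens), read by FLIPR, with a stated time of 1 h (a higher number here means a weaker inhibitor, a lower number a stronger inhibitor), compound 1 `CC(C)CN1CCc2nc(C#Cc3ccccc3)sc2C1` gives 650 nM. Compound 2 `CC1CC1C(=O)N1CCc2nc(C#Cc3ccccc3)sc2C1` reaches only the limit of this assay, > 10000 nM. Compound 3 `O=C(C1CCCC1)N1CCc2nc(C#Cc3ccccc3)sc2C1` likewise sits at the limit, > 10000 nM, so no number is read for it. Exchanging the isobutyl on the amine nitrogen in the ring for a ring-bearing carbonyl gave an at least 15-fold higher number from compound 1 to compound 2 (1.18 log units; beyond the scatter) and an at least 15-fold higher number from compound 1 to compound 3 (1.18 log units; beyond the scatter). Because of the limit of > 10000 nM in this assay, at which 2 of the 3 values shown sit, the step that the two limits leave unreadable from compound 2 to compound 3 cannot be read. Compound 4 `O=C(C1CCCCO1)N1CCc2nc(C#Cc3ccccc3)sc2C1` keeps that carbonyl and differs from compound 3 in oxan-2-yl in place of cyclopentyl on a carbonyl carbon. Both carbonyl compounds seen so far sit at the limit, and no exchange of the ring on the carbonyl has yet produced a readable number. Compound 4 is therefore expected to remain at the limit, a step that the limit leaves unreadable from compound 3 to compound 4, with an estimate of 15000 nM between 5000 nM and 50000 nM.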

Compound 4, half-maximal inhibitory concentration: > 10000 nM
Compound 4: only a limit was reported; the forecaster's own chance of this, stated with the estimate: 75%; the middle value is on the limit's open side.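

In this assay compound 4 gives > 10000 nM, which is a limit and not a number. Oxan-2-yl, a ring holding an oxygen, thus joins the carbon-only rings on the carbonyl in giving no readable value, and the change from isobutyl gives an at least 15-fold higher number from compound 1 to compound 4 (1.18 log units; beyond the scatter). The steps among compound 2, compound 3 and compound 4 cannot be read: the limit of > 10000 nM in this assay, at which 3 of the 4 values shown sit.

On these data alone, whether a carbonyl carrying an amine or a carboxylic acid would give a readable number stays open. Also open, as far as these compounds go, is how a longer chain in place of isobutyl, with no carbonyl, would compare with compound 1 at 650 nM.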